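The source may report more compounds than this note shows. Statements on the series, on what has been measured and on what is new or still open speak of the compounds shown alone.

Compounds measured in a functional assay on cells (Lymphocyte), read by a luciferase reporter and ATP content, with a stated time of 48 h, tested at 25 uM; a higher number here means a weaker effect of the compound at the concentration tested, a lower number a stronger effect:
compound 1 `CCCCCCCCCCCCCCCCc1c(C)c(N(C)C)nc(C)c1O`, 37%;
compound 2 `CCCCCCCCCCc1c(C)c(N(C)C)nc(C)c1O`, 2%;
compound 3 `Cc1c(N(C)C)nc(CCCCCCCCCCO)c(O)c1C`, 3%.

Compound 3 stands second highest of the three numbers; compound 2 lies within the scatter of it, compound 1 lies beyond the scatter above it. Compound 4 `CCCCCCCCCCc1nc(N(C)C)c(C)c(C)c1O` differs from compound 3 by hydrogen in place of hydroxy on a saturated chain carbon, ten or more bonds along the chain from an aromatic carbon. For the measured compounds named here, the one step measured, a number 35 percentage points lower from compound 1 to compound 2 (beyond the scatter), concerns a different change on the chain and a much larger loss; no step removes a hydroxy. Compound 2, which carries a plain decyl chain, and compound 3, which carries a chain ending in hydroxy, read within the scatter of each other, though their chains sit on different ring carbons. No step beyond the scatter is therefore expected, a number 2 percentage points higher from compound 3 to compound 4 (within the scatter). Compound 4 is estimated at 5%, within 0% to 25%.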

Compound 4, a percentage reported as activity, at one concentration (the size of the read-out at that concentration, not a potency): 13%
Compound 4: the middle estimate sits 8 percentage points below what was measured; the measured number falls inside the stated range.
By their numbers in this assay, from the lowest: compounds 2, 3 and 4 (each within the scatter of the next, the first and the last beyond it); then compound 1.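

In this assay, hydrogen in place of hydroxy on a saturated chain carbon, ten or more bonds along the chain from an aromatic carbon, reads as a number 10 percentage points higher from compound 3 to compound 4 (within the scatter) and so gives no separation between the two chains. At this position the hydroxy is therefore not required for a low number at the concentration tested. No measurement available here bears on the reason for this result.

On these data alone, whether an amine or a carboxylic acid in place of the hydroxy would read the same remains open. So does the reading of a shorter chain carrying the hydroxy.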